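Series notes: cytotoxicity readings and the step to compound 3

The source may report more compounds than this note shows. Statements on the series, on what has been measured and on what is new or still open speak of the compounds shown alone.

Measured so far:
compound 1 `CCc1ccc(NC(=O)Nc2cc(C)nc3ccccc23)cc1` gives > 25000 nM
compound 2 `Cc1cc(NC(=O)Nc2cc(F)cc(F)c2)c2ccccc2n1` gives > 25000 nM

Both values obtained in an ADME assay on Raji cells (Homo sapiens) for cytotoxicity, with a stated time of 72 h (a higher number here means that more compound is needed for the effect, a lower number that less compound is needed), are limits of the assay rather than numbers. For compound 1 the reading > 25000 nM is such a limit. For compound 2 the reading > 25000 nM is likewise a limit. Among the compounds with values here, compound 1 therefore stands at the limit of > 25000 nM in this assay, at which 2 of the 2 values shown sit, and nothing in the data separates the two measured compounds from each other; no step between them can be stated.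

The unmeasured compound 3 `Cc1cc(NC(=O)Nc2ccc(C(=O)O)cc2)c2ccccc2n1` differs from compound 1 by carboxy in place of ethyl on an aromatic carbon. Within the data shown here, no measured step calibrates a change of this kind, so the expectation rests on where the measured compounds sit.

With both measured readings at the limit, compound 3 is expected to return a limit as well, and the expected step that the limit leaves unreadable from compound 1 to compound 3 is none beyond the scatter. For compound 3 the estimate in this assay is 40000 nM, with a range of 15000 nM to 120000 nM.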

Compound 3, half-maximal effective concentration: > 25000 nM
Compound 3 ended at the assay's limit; the forecaster's own chance of this, stated with the estimate: 80%; the middle value is on the limit's open side.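

In this assay compound 3 gives > 25000 nM, a limit of the assay. Within the data shown here, with compound 1 also at a limit, no step from compound 1 to compound 3 can be read for carboxy in place of ethyl. The compounds shown leave open what number lies behind these readings and whether any change brings a reading off the limit: the limit of > 25000 nM in this assay, at which 3 of the 3 values shown sit.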